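The source may hold more compounds than are shown below. What is called first, only, known or untested is meant among the compounds shown, and "the series" means these compounds.

Series notes. Compound 1 `O=C(Nc1ccc(Oc2ccnc3[nH]ccc23)cc1)c1cc2cccnc2n(-c2ccc(Cl)cc2)c1=O` gives 3370 nM in a functional assay on U-87MG ATCC cells for antiproliferative activity against U-87 MG (Homo sapiens), read by MTT assay, with a stated time of 72 h; on this read-out higher numbers stand for weaker inhibition and lower numbers for stronger inhibition. Compound 2 `Cn1ccc2c(Oc3ccc(NC(=O)c4cc5cccnc5n(-c5ccc(F)cc5)c4=O)cc3)ccnc21` gives 2120 nM in this assay; these two compounds differ in more than one place, so their values are simply recorded side by side. Compound 3 `Cn1ccc2c(Oc3ccc(NC(=O)c4cc5cccnc5n(-c5ccc(Cl)cc5)c4=O)cc3)ccnc21` gives "not determined" (no result reported) in this assay, so compound 3 stands without a number among these results and offers no anchor of its own. Compound 4 `Cn1ccc2c(Oc3ccc(NC(=O)c4cc5cccnc5n(-c5ccc(C(F)(F)F)cc5Cl)c4=O)cc3)ccnc21` differs from compound 3 by 2-chloro-4-(trifluoromethyl)phenyl in place of 4-chlorophenyl on an aromatic nitrogen. Among the measured compounds shown here, no measured step covers this change, so its size in this assay cannot be read from the data; the expectation is a shift of no more than the usual scatter, in either direction, from the level that compound 1 and compound 2 set. Compound 4 is expected to give 2500 nM, with a range from 600 nM to 10000 nM.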

Compound 4, half-maximal inhibitory concentration: 12600 nM
Compound 4: middle estimate off by 5.0-fold (0.70 log units), on the low side; the whole stated range lies below it.
By their numbers in this assay, from the lowest: compounds 2 and 1 (each within the scatter of the next); then compound 4.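

In this assay the aryl group on the aromatic nitrogen shows a 5.9-fold higher number from compound 2 to compound 4 (0.77 log units; beyond the scatter) on going from 4-fluorophenyl to 2-chloro-4-(trifluoromethyl)phenyl, so the number responds to this position. The step from compound 3 cannot be read, since compound 3 has no number. Nothing on hand bears on why the number rises.

Still open, on these data alone, is whether the chlorine or the trifluoromethyl carries the step, since both change together here. Also open, as far as these compounds go, is how a simple methyl group or a 4-methoxyphenyl on this nitrogen would read.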